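Removing One Chloro From Compound 2

This account rests on a few compounds, and the source may have more. Where it says the series, first, only, none or still open, it means among the compounds named here.

Among the compounds with values here, compound 2 `ClCc1ccc(Cn2cnc3nc(Cl)nc(Cl)c32)cc1` holds the lower of the two numbers measured so far in a functional assay on SK-MEL-2 cells (Homo sapiens) for cytotoxicity, read by sulforhodamine B assay, with a stated time of 48 h; a lower number here means a stronger inhibitor of growth, a higher number a weaker inhibitor of growth: compound 2 gives 1120 nM, whereas compound 1 `ClCc1cccc(Cn2cnc3c(Cl)ncnc32)c1` gives 21900 nM, a gap well beyond the scatter. Compound 3 `ClCc1ccc(Cn2cnc3ncnc(Cl)c32)cc1` differs from compound 2 in one place: hydrogen in place of chloro on an aromatic carbon, on the carbon between two ring nitrogen atoms. Within the data shown here, no measured pair shows this change alone; compound 1 also lacks this chloro but differs from compound 3 elsewhere as well. A weakening step is expected, a 4.5-fold higher number from compound 2 to compound 3 (0.65 log units; beyond the scatter). Compound 3 is estimated at 5000 nM, within 1500 nM to 20000 nM.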

Compound 3, concentration for 50% growth inhibition: 6300 nM
The estimate for compound 3 lay 1.3-fold (0.10 log units) below the measured number, within the range that was stated.
By their numbers in this assay, from the lowest: compound 2; then compound 3; then compound 1.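

In this assay the chloro on the carbon between two ring nitrogen atoms now has a step of its own: hydrogen in its place gives a 5.6-fold higher number from compound 2 to compound 3 (0.75 log units; beyond the scatter) and nothing else in the structure changes. Compound 1 could not show this, as it differs from compound 3 in more than one place. The data shown give no cause for this step.

From the compounds shown here alone, whether an amine or a methoxy group on this carbon would match the chloro or hydrogen remains open. So does the part played by the remaining chloro of compound 3.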